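Bromo in Place of Methyl and Cytotoxicity in HeLa Cells

The compounds below may be only part of what the source reports. "The series", "measured", "known", "first", "only" and "open" are said of these compounds alone.

Compound 1 `Cc1cccc(/C=C/c2ncc([N+](=O)[O-])n2C)c1` gives 30900 nM in an ADME assay on HeLa cells (Homo sapiens) for cytotoxicity, read by resazurin assay, with a stated time of 2 days; a higher number here means a weaker inhibitor, a lower number a stronger inhibitor.
Compound 2 `Cc1ccc(/C=C/c2ncc([N+](=O)[O-])n2C)cc1` gives only a limit of the assay, > 100000 nM, in this assay.
Compound 3 `Cn1c([N+](=O)[O-])cnc1/C=C/c1cccc(Br)c1` gives 87100 nM in this assay.

Compound 1 and compound 2 share the same atoms joined differently; the difference between the two cores is not broken down here. From compound 1 to compound 3 the change is bromo in place of methyl on an aromatic carbon, and in this assay it gives a 2.8-fold higher number from compound 1 to compound 3 (0.45 log units; beyond the scatter). Compound 4 `Cn1c([N+](=O)[O-])cnc1/C=C/c1ccc(Br)cc1` has not yet been measured. It differs from compound 2 by bromo in place of methyl on an aromatic carbon; the place differs, meta to a large group in the first pair and para to a large group in the second, so this is the same kind of change rather than the same change. Compound 2 already sits at the limit of > 100000 nM in this assay, at which 1 of the 3 values shown sits. The step from compound 2 to compound 4 is therefore expected to be a step that the limit leaves unreadable from compound 2 to compound 4, resting on the modest weakening seen in a 2.8-fold higher number from compound 1 to compound 3 (0.45 log units; beyond the scatter) and on compound 2 being at the limit. Compound 4 is expected to give about 200000 nM in this assay, between 80000 nM and 500000 nM, most likely reported only as a limit.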

Compound 4, half-maximal inhibitory concentration: 72400 nM
Estimate against measurement, compound 4: 2.8-fold (0.44 log units) above; measured number outside the range, below it.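

In this assay bromo in place of methyl, on an aromatic carbon para to a large group, gives an at least 1.3-fold lower number from compound 2 to compound 4 (0.14 log units; that floor lies within the scatter), and set beside the earlier pair, the change does not carry over as one fixed step: the same change on two cores in this assay, a 2.8-fold higher number (0.45 log units; beyond the scatter) from compound 1 to compound 3 and an at least 1.3-fold lower number (0.14 log units; that floor lies within the scatter) from compound 2 to compound 4, at least 3.8-fold (0.59 log units) apart, beyond the scatter of two such steps

Compound 2 gives > 100000 nM as a limit of the assay and not a number. The true size of the new step therefore stays unread, and since the two pairs differ in the place of the change as well as in the core, the result does not show whether core or place sets the gap between them.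

The compounds shown leave open how chloro, methoxy or an amine on the same aromatic ring would read in this assay on either core. They also leave open whether a longer chain in place of methyl would separate the two cores in the same way.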